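The source may hold more compounds than are shown below. What is called first, only, known or untested is meant among the compounds shown, and "the series" means these compounds.

Measured so far in an ADME assay on HepG2 2.2.15 cells (Homo sapiens) for cytotoxicity; a higher number here means that more compound is tolerated, a lower number that less compound is tolerated:
- Compound 1, `CCCCC(=O)OCCc1c(-c2ccccc2Cl)c2cc(Cl)ccc2[nH]c1=O`: compound 1 gives 200000 nM.
- Compound 2, `O=C(OCCc1c(-c2ccccc2Cl)c2cc(Cl)ccc2[nH]c1=O)C1CCCC1`: compound 2 gives 46000 nM.
- Compound 3, `CC12CCC(C(=O)OCCc3c(-c4ccccc4Cl)c4cc(Cl)ccc4[nH]c3=O)(OC1=O)C2(C)C`: for compound 3 the assay reports only a limit, > 1800000 nM.

Compound 1 holds the higher of the two plain numbers in this assay; its nearest neighbour is compound 2, reached by a 4.3-fold lower number from compound 1 to compound 2 (0.64 log units; beyond the scatter). The result for compound 3 is a limit rather than a number (the limit of > 1800000 nM in this assay, at which 1 of the 3 values shown sits).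

Compound 4, `O=C(OCCc1c(-c2ccccc2Cl)c2cc(Cl)ccc2[nH]c1=O)c1ccc([N+](=O)[O-])cc1`, has not yet been measured. It differs from compound 1 by 4-nitrophenyl in place of butyl on a carbonyl carbon. Two measured steps start from compound 1 and alter the same position on the carbonyl carbon: a 4.3-fold lower number from compound 1 to compound 2 (0.64 log units; beyond the scatter) lowered the number, while an at least 9.0-fold higher number from compound 1 to compound 3 (0.95 log units; beyond the scatter) raised it. Neither of those steps brings in an aromatic ring, so the direction for compound 4 is open; a modest step either way, or none beyond the scatter, seems plausible. Compound 4 is therefore expected to come out at 150000 nM, between 40000 nM and 600000 nM. That expectation amounts to an estimated step of a 1.3-fold lower number from compound 1 to compound 4 (0.12 log units; within the scatter).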

Compound 4, half-maximal cytotoxic concentration: 1600000 nM
Beside the measured number, compound 4's estimate is 11-fold (1.03 log units) below it; measured number above the stated range.
By their numbers in this assay, from the lowest: compound 2; then compound 1; then compound 4. At a limit, above all of these: compound 3.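

In this assay, the earlier compounds had shown this position on the carbonyl carbon moving both ways, with non-aromatic groups only. 4-Nitrophenyl, the only aromatic ring at this position among these compounds, gives an 8.0-fold higher number from compound 1 to compound 4 (0.90 log units; beyond the scatter) in place of butyl, and a 35-fold higher number from compound 2 to compound 4 (1.54 log units; beyond the scatter) in place of cyclopentyl, so in these two steps 4-nitrophenyl goes with more compound being tolerated than either of those carbon groups. Compound 3 carries only a limit: the limit of > 1800000 nM in this assay, at which 1 of the 4 values shown sits. Against that limit the comparison reads only as an at least 1.1-fold lower number from compound 3 to compound 4 (0.05 log units; that floor lies within the scatter), so it sets no order between the two.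

The compounds shown do not separate the ring from its nitro group, so the change could belong to either. A plain phenyl or a 4-aminophenyl at the same place would be needed to tell the two apart.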